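The compounds below may be only part of what the source reports. "The series", "measured", "known", "first", "only" and "open" are said of these compounds alone.

Measured so far in a functional assay on MCF7 cells (Homo sapiens) for cytotoxicity, read by MTT assay, with a stated time of 72 h (on this read-out lower numbers stand for stronger inhibition and higher numbers for weaker inhibition), for this series:
- compound 1 `COc1ccc(/C=C2\CCC/C(=C\c3ccccc3Cl)C2=O)cc1OC` gives 10400 nM as its value
- compound 2 `COc1ccc(/C=C2\CCC/C(=C\c3cccc(Cl)c3Cl)C2=O)cc1OC` gives 14300 nM as its value

Compound 2 stands within the scatter of compound 1, so the two mark a single level. Next comes compound 3 `COc1ccc(/C=C2\CCC/C(=C\c3ccc(O)c(O)c3)C2=O)cc1OC`, which has 3,4-dihydroxyphenyl in place of 2,3-dichlorophenyl on a double-bonded chain carbon bound to a double-bonded ring carbon as its only change. For the measured compounds named here, the one measured step, a 1.4-fold higher number from compound 1 to compound 2 (0.14 log units; within the scatter) for chloro in place of hydrogen on an aromatic carbon, stays within the scatter. Going by the values given here, it is a weak guide, since no measured compound carries a hydroxy group. Only a modest move to a lower number is therefore expected, with little confidence in its direction. The estimated step is a 2.0-fold lower number from compound 2 to compound 3 (0.31 log units; beyond the scatter) in this assay on this reasoning. For compound 3 the estimated value is 7000 nM with a range from 1800 nM to 22000 nM as the expected span.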

Compound 3, half-maximal inhibitory concentration: 14400 nM
Compound 3: middle estimate off by 2.1-fold (0.31 log units), on the low side, within the range that was stated.
By their numbers in this assay, from the lowest: compounds 1, 2 and 3 (each within the scatter of the next).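

In this assay, replacing 2,3-dichlorophenyl by 3,4-dihydroxyphenyl on a double-bonded chain carbon bound to a double-bonded ring carbon gives a 1.0-fold higher number from compound 2 to compound 3 (0.00 log units; within the scatter), and replacing 2-chlorophenyl by the same group gives a 1.4-fold higher number from compound 1 to compound 3 (0.14 log units; within the scatter). Chlorinated and hydroxylated phenyl groups at this place therefore sit at one level, although 3,4-dihydroxyphenyl has 2 hydrogen-bond donors and 2 hydrogen-bond acceptors where 2,3-dichlorophenyl has 0 of each, so these counts do not separate the compounds here. No supporting data bear on this flat result.

From the compounds shown here alone, it remains open whether any group at this place, such as an amine, a carboxylic acid or a longer chain in place of the phenyl ring, gives a step beyond the scatter. Going by these compounds, the effect of changes elsewhere is also open, since all three compounds keep the rest of the shared core unchanged.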